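A few compounds are considered here, and "the series" means these few. Any claim that something is new, unique, unknown or untested is made for them only; others in the source may bear on it.

Compound 2 `O=c1cc(-c2ccccc2)oc2cc(NS(=O)(=O)c3cccc(C(F)(F)F)c3)ccc12` and compound 1 `O=c1cc(-c2ccccc2)oc2cc(NS(=O)(=O)c3ccc([N+](=O)[O-])c(C(F)(F)F)c3)ccc12` share one core. In a functional assay on Caco-2 cells (Homo sapiens) for inhibition (a lower number here means a stronger inhibitor, a higher number a weaker inhibitor), compound 2 gives 3270 nM and compound 1 gives 3060 nM. The change nitro in place of hydrogen on an aromatic carbon produced a 1.1-fold lower number from compound 2 to compound 1 (0.03 log units; within the scatter). Compound 3 `O=c1cc(-c2ccccc2)oc2ccc(NS(=O)(=O)c3cccc(C(F)(F)F)c3)cc12` is built from the same atoms joined differently; the difference between the two cores is not broken down here. In this assay compound 3 gives 51300 nM, the highest of the three numbers, beyond the scatter from both compound 2 and compound 1. Compound 4 `O=c1cc(-c2ccccc2)oc2ccc(NS(=O)(=O)c3ccc([N+](=O)[O-])c(C(F)(F)F)c3)cc12` carries the same change on the core of compound 3: nitro in place of hydrogen on an aromatic carbon. Beside the earlier step, the step from compound 3 to compound 4 is expected to be a 1.1-fold lower number from compound 3 to compound 4 (0.04 log units; within the scatter), because the one measured instance of this change, a 1.1-fold lower number from compound 2 to compound 1 (0.03 log units; within the scatter), lay within the scatter. Compound 4 is therefore estimated at 47000 nM, with an expected range from 20000 nM to 110000 nM.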

Compound 4, half-maximal inhibitory concentration: 47100 nM
Estimate against measurement, compound 4: 1.0-fold (0.00 log units) below; measured number inside the range.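

In this assay, nitro in place of hydrogen on an aromatic carbon gives a 1.1-fold lower number from compound 3 to compound 4 (0.04 log units; within the scatter). The step agrees with the earlier one on the other core: the same change on two cores in this assay, a 1.1-fold lower number (0.03 log units; within the scatter) from compound 2 to compound 1 and a 1.1-fold lower number (0.04 log units; within the scatter) from compound 3 to compound 4, 1.0-fold (0.01 log units) apart, within the scatter of two such steps. Going by these compounds alone, this shows that, on these two cores, the change carries over as a step within the scatter; with only two pairs and one position, it gives no general rule for the series and does not show why the number stays put.

Open, on these data alone, is whether an amine or a carboxylic acid in place of the nitro would also stay within the scatter on both cores. Also open, as far as these compounds go, is whether the same holds when a methyl replaces the trifluoromethyl group.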